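The compounds below may be only part of what the source reports. "The series", "measured", "known", "first", "only" and "open" are said of these compounds alone.

Measured so far: compound 1 `CC[C@H](C)[C@@H]1C(=O)N[C@H](C2Cc3ccccc3C2)C(=O)N1[C@@H](C(=O)N(C)C)c1ccc(C)nc1C`, compound 2 `CC[C@H](C)[C@@H]1C(=O)N[C@H](C2Cc3ccccc3C2)C(=O)N1[C@@H](C(=O)N1CCOCC1)c1ccc(C)nc1` and compound 3 `CCC(CC)[C@@H]1C(=O)N[C@H](C2Cc3ccccc3C2)C(=O)N1[C@@H](C(=O)N1CCOCC1)c1ccc(C)nc1C`. In an in vivo ADME assay on the whole organism for pharmacokinetics, with Rattus norvegicus as the target, at a dose of 5 mg/kg by the oral route (a higher number here means that a larger share of the oral dose reaches the circulation, a lower number that a smaller share of the oral dose reaches the circulation), compound 1 gives 84%. In this assay compound 2 gives 54%. In this assay compound 3 gives 42%.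

Compound 2 thus stands second highest of the three: compound 3 lies below it beyond the scatter, and compound 1 lies above it beyond the scatter.

Compound 4 `CC[C@@H](C)[C@@H]1C(=O)N[C@H](C2Cc3ccccc3C2)C(=O)N1[C@@H](C(=O)N1CCOCC1)c1ccc(C)nc1` has not yet been measured. (the two compounds have the same atoms and bonds and differ only in configuration as drawn: 1 of 4 stereo elements differ; a stereocentre at a saturated chain carbon is drawn S in compound 2 and R in compound 4). Among the measured compounds shown here, no pair of measured compounds shows what such a change of configuration does in this assay, so the direction is open; a step beyond the scatter, most likely downward, is expected but uncertain. Compound 4 is therefore estimated at 45%, within 20% to 75%, an expected step of a number 9 percentage points lower from compound 2 to compound 4 (within the scatter).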

Compound 4, oral bioavailability: 44%
Compound 4: the middle estimate sits 1 percentage points above what was measured; low and high end bracket the measured number.
By their numbers in this assay, from the lowest: compounds 3, 4 and 2 (each within the scatter of the next, the first and the last beyond it); then compound 1.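

Turning the stereocentre at the saturated chain carbon from S to R gives, in this assay, a number 10 percentage points lower from compound 2 to compound 4 (within the scatter). Among the compounds shown here, this is the first reading of configuration at this carbon, and it rests on a single pair in which nothing else can account for the step: the fact that compounds 2 and 4 differ only in the configuration as drawn.

The compounds shown leave open whether the same change would read alike on the core of compound 1 or compound 3, and what changing the other stereo elements would give. They also leave open what a cyclopentyl group or a longer chain would give in place of the chain carrying this stereocentre.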